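The source may hold more compounds than are shown below. What is called first, only, known or untested is meant among the compounds shown, and "the series" means these compounds.

Within the data shown here, the two compounds measured so far share one core and differ only in a single group on an outer aromatic ring. Compound 1 `Cc1c(C(=O)NCCCN2CCN(C)CC2)c(-c2cccc(N3CCN(c4ccc(NS(=O)(=O)c5cccc(OC(F)(F)F)c5)cc4)CC3)c2)c(-c2ccc(Cl)cc2)n1C` carries a trifluoromethoxy group there, and in an assay for binding affinity to Apoptosis regulator Bcl-2 (Homo sapiens), read by fluorescence polarization, with a stated time of 2 h (on this read-out lower numbers stand for stronger inhibition and higher numbers for weaker inhibition), compound 1 gives 197 nM. Compound 2 `Cc1c(C(=O)NCCCN2CCN(C)CC2)c(-c2cccc(N3CCN(c4ccc(NS(=O)(=O)c5cccc(S(=O)(=O)C(F)(F)F)c5)cc4)CC3)c2)c(-c2ccc(Cl)cc2)n1C` carries a (trifluoromethyl)sulfonyl group in its place, and in this assay compound 2 gives 39.2 nM. Among the measured compounds shown here, that exchange is the one step measured between them, a 5.0-fold lower number from compound 1 to compound 2 (0.70 log units; beyond the scatter), so compound 2 holds the lower of the two numbers and compound 1 the higher. Compound 3 `Cc1cccc(S(=O)(=O)Nc2ccc(N3CCN(c4cccc(-c5c(C(=O)NCCCN6CCN(C)CC6)c(C)n(C)c5-c5ccc(Cl)cc5)c4)CC3)cc2)c1` is the next step from compound 2: methyl in place of (trifluoromethyl)sulfonyl on an aromatic carbon. For the measured compounds named here, no measured pair shows this exact exchange; the only step that bears on it is the one from compound 1 to compound 2, where the (trifluoromethyl)sulfonyl group belonged to the version with the lower number, and that step was modest in size. Because compound 2 sits at 39.2 nM with that group in place, giving it up for methyl is expected to raise the number, by about a 4.1-fold higher number from compound 2 to compound 3 (0.61 log units; beyond the scatter). The value of compound 3 in this assay is therefore estimated at 160 nM, most likely between 50 nM and 500 nM.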

Compound 3, inhibition constant: 178 nM
Compound 3: middle estimate off by 1.1-fold (0.05 log units), on the low side; measured number inside the range.
By their numbers in this assay, from the lowest: compound 2; then compounds 3 and 1 (each within the scatter of the next).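

In this assay, the step of a 4.5-fold higher number from compound 2 to compound 3 (0.66 log units; beyond the scatter) shows that the lower number of compound 2 is not specific to the comparison with trifluoromethoxy, since it also holds against methyl, a group of a single heavy atom. The step of a 1.1-fold lower number from compound 1 to compound 3 (0.04 log units; within the scatter) adds that methyl and trifluoromethoxy cannot be told apart at this position, so among the three groups on this aromatic carbon only (trifluoromethyl)sulfonyl stands apart, with both of its steps beyond the scatter. No measurement shown here explains why this group goes with the lower number.

The compounds shown leave open which part of the group matters, the sulfonyl or the trifluoromethyl, a question that a methylsulfonyl group or a plain trifluoromethyl group on the same carbon could help to settle. They also leave open how an amine or a carboxylic acid would compare on this carbon, and whether (trifluoromethyl)sulfonyl would give a similar number on a different carbon of this ring.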